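The source may report more compounds than this note shows. Statements on the series, on what has been measured and on what is new or still open speak of the compounds shown alone.

Measured in a functional assay on HT-29 cells (Homo sapiens) for cytotoxicity, read by MTT assay, with a stated time of 72 h; a higher number here means a weaker inhibitor, a lower number a stronger inhibitor:
compound 1 `CN(C)CCn1cnnc1-c1cc(Oc2ccc(NC(=O)N/N=C/c3cccc(Br)c3)cc2F)ccn1` gives 380 nM
compound 2 `CN(C)CCn1cnnc1-c1cc(Oc2ccc(NC(=O)N/N=C/c3ccc(O)c(F)c3)cc2F)ccn1` gives 3310 nM
compound 3 `Cc1cc(/C=N/NC(=O)Nc2ccc(Oc3ccnc(-c4nncn4CCN(C)C)c3)c(F)c2)cc(C)c1O` gives 1220 nM

Compound 2 stands highest of the three, both of its neighbours sitting beyond the scatter: a 2.7-fold lower number from compound 2 to compound 3 (0.43 log units; beyond the scatter), and the larger gap an 8.7-fold higher number from compound 1 to compound 2 (0.94 log units; beyond the scatter). Compound 4 `COc1ccc(/C=N/NC(=O)Nc2ccc(Oc3ccnc(-c4nncn4CCN(C)C)c3)c(F)c2)c(OC)c1OC` is not yet measured. Its change from compound 2 is 2,3,4-trimethoxyphenyl in place of 3-fluoro-4-hydroxyphenyl on a carbon with a double bond to nitrogen. Both earlier steps bear on it, since each replaces or installs the 3-fluoro-4-hydroxyphenyl on the carbon with a double bond to nitrogen, and each leaves that group with the higher number. A modest lowering in this assay is therefore expected for compound 4, as a 2.8-fold lower number from compound 2 to compound 4 (0.44 log units; beyond the scatter). Compound 4 is estimated at 1200 nM in this assay, within a range of 400 nM to 4000 nM.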

Compound 4, half-maximal inhibitory concentration: 3970 nM
Estimate against measurement, compound 4: 3.3-fold (0.52 log units) below; measured number inside the range.
By their numbers in this assay, from the lowest: compound 1; then compound 3; then compounds 2 and 4 (each within the scatter of the next).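

In this assay, the 2,3,4-trimethoxyphenyl group, with 0 hydrogen-bond donors, cannot be told apart from the 3-fluoro-4-hydroxyphenyl group (a 1.2-fold higher number from compound 2 to compound 4 (0.08 log units; within the scatter)). Lack of a hydrogen-bond donor alone therefore does not set the number at this position: 3-bromophenyl also lacks a phenol hydroxyl, yet a 10-fold higher number from compound 1 to compound 4 (1.02 log units; beyond the scatter), while the hydroxyl-bearing 4-hydroxy-3,5-dimethylphenyl group gives a 3.3-fold higher number from compound 3 to compound 4 (0.51 log units; beyond the scatter). Nothing available explains these steps. Open, going by these compounds, is whether a chlorine or a trifluoromethyl group in place of the bromine would keep the low number of compound 1, and how an amine on the same phenyl ring would read.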